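Swapping hydroxy for methylamino on a second benzophenone core

The compounds below may be only part of what the source reports. "The series", "measured", "known", "first", "only" and "open" are said of these compounds alone.

Compound 1 `COc1ccc(C(=O)c2ccc3c(c2)C=CC(C)(C)O3)c(NC(=O)CO)c1` and compound 2 `CNCC(=O)Nc1cc(OC)ccc1C(=O)c1ccc2c(c1)C=CC(C)(C)O2` share one core and differ by methylamino in place of hydroxy on a saturated chain carbon bound to a carbonyl carbon. In a functional assay on A549 cells (Homo sapiens) for antiproliferative activity, read by MTT assay, with a stated time of 48 h (on this read-out higher numbers stand for weaker inhibition and lower numbers for stronger inhibition), compound 1 gives 90 nM, while compound 2 gives 800 nM, so that an 8.9-fold higher number from compound 1 to compound 2 (0.95 log units; beyond the scatter). Compound 3 `COc1ccc(C(=O)c2cc(OC)c(OC)c(OC)c2)c(NC(=O)CO)c1` carries a different core; the difference between the two cores is not broken down here. In this assay compound 3 gives 70 nM. Compound 4 `CNCC(=O)Nc1cc(OC)ccc1C(=O)c1cc(OC)c(OC)c(OC)c1` is related to compound 3 by methylamino in place of hydroxy on a saturated chain carbon bound to a carbonyl carbon, the same change as that from compound 1 to compound 2. For the measured compounds named here, since the earlier step is the only guide, compound 4 is expected to show an 8.9-fold higher number from compound 3 to compound 4 (0.95 log units; beyond the scatter), resting on an 8.9-fold higher number from compound 1 to compound 2 (0.95 log units; beyond the scatter). In this assay compound 4 is therefore estimated at 620 nM, with a likely range from 250 nM to 1500 nM.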

Compound 4, half-maximal inhibitory concentration: 610 nM
Compound 4: the middle estimate sits 1.0-fold (0.01 log units) above what was measured, within the range that was stated.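

On the core of compound 3, methylamino in place of hydroxy gives an 8.7-fold higher number from compound 3 to compound 4 (0.94 log units; beyond the scatter) in this assay. This result covers one change on two cores in one assay, so it does not show that the step would keep its size on any other core, nor does it say why the number rises. Within those limits the change carries over from one core to the other at the same size: the same change on two cores in this assay, an 8.9-fold higher number (0.95 log units; beyond the scatter) from compound 1 to compound 2 and an 8.7-fold higher number (0.94 log units; beyond the scatter) from compound 3 to compound 4, 1.0-fold (0.01 log units) apart, within the scatter of two such steps

The compounds shown leave open how a dimethylamino group, a primary amine or a longer chain would behave in place of hydroxy on this saturated chain carbon. They also leave open whether the step would hold on a third core or in another cell line.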